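Phenyl for naphthalenyl on the amide nitrogen

The source may report more compounds than this note shows. Statements on the series, on what has been measured and on what is new or still open speak of the compounds shown alone.

Three compounds in this series carry a measured value in a functional assay on NCI-H661 cells (Homo sapiens) for antiproliferative activity, read by MTT assay, with a stated time of 72 h; on this read-out higher numbers stand for weaker inhibition of growth and lower numbers for stronger inhibition of growth. Compound 1 `O=C(COc1c(-c2ccccc2)oc2ccccc2c1=O)Nc1ccc2ccccc2c1` gives 6500 nM in this assay. Compound 3 `O=C(COc1ccc2c(=O)cc(-c3ccccc3)oc2c1)Nc1ccc(F)cc1` gives 5770 nM in this assay. Compound 2 `O=C(COc1ccc2c(=O)c(-c3ccccc3)coc2c1)Nc1ccc2ccccc2c1` gives only a limit in this assay, > 10000 nM. Compound 2 therefore stands at the weak end of the numbers shown, at the limit of > 10000 nM in this assay, at which 1 of the 3 values shown sits, with no number of its own. Among the compounds with values here, the values of compound 1 and compound 3 lie close to one another, and each belongs to a core that differs from the core of compound 2, so no measured step joins any pair of these three.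

Compound 4 `O=C(COc1ccc2c(=O)c(-c3ccccc3)coc2c1)Nc1ccccc1` shares the core of compound 2 and differs from it by phenyl in place of naphthalen-2-yl on an amide-type nitrogen. Within the data shown here, no measured step covers this change anywhere, so the expected step in this assay is none beyond the scatter, in no particular direction, and compound 4 is expected to remain near the weak end where compound 2 sits. Compound 4 is estimated at 10000 nM in this assay, with a range from 3000 nM to 30000 nM. That estimate means an expected step of a number no higher from compound 2 to compound 4 (the limit leaves the size open).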

Compound 4, concentration for 50% growth inhibition: > 10000 nM
Compound 4 gave a limit, no number; the forecaster's own chance of this, stated with the estimate: 55%; the middle value sits exactly at the limit.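

Compound 2 and compound 4 both end at a limit in this assay, so no step can be read for phenyl in place of naphthalen-2-yl on an amide-type nitrogen: the limit of > 10000 nM in this assay, at which 2 of the 4 values shown sit.

The compounds shown leave open whether these two groups differ at all in their effect on growth on the core shared by compound 2 and compound 4.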